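This account rests on a few compounds, and the source may have more. Where it says the series, first, only, none or still open, it means among the compounds named here.

Of the compounds shown here, three of one family have been tested in an assay on isolated protein for binding affinity to fibroblast growth factor 2 (Homo sapiens), read by surface plasmon resonance; a lower number here means tighter binding, a higher number weaker binding. Compound 1 `CC(=O)N[C@H]1[C@@H](OC[C@@H](O)[C@@H](O)[C@H](O)[C@@H](O)CNc2cccc(NC(=O)CCCCC3CCSS3)c2)O[C@H](CO)[C@H](OS(=O)(=O)O)[C@@H]1O[C@@H]1O[C@H](C(=O)O)[C@@H](O)[C@H](O)[C@H]1O` gives "not active" (no number reported) in this assay. Compound 2 `CC(=O)N[C@H]1[C@@H](OC[C@@H](O)[C@@H](O)[C@H](O)[C@@H](O)CNc2cccc(NC(=O)CCCCC3CCSS3)c2)O[C@H](COS(=O)(=O)O)[C@H](OS(=O)(=O)O)[C@@H]1O[C@@H]1O[C@H](C(=O)O)[C@@H](O)[C@H](O)[C@H]1O` gives 16 nM in this assay. Compound 3 `CC(=O)N[C@H]1[C@@H](OC[C@@H](O)[C@@H](O)[C@H](O)[C@@H](O)CNc2cccc(NC(=O)CCCCC3CCSS3)c2)O[C@H](CO)[C@H](OS(=O)(=O)O)[C@@H]1O[C@@H]1O[C@H](C(=O)O)[C@@H](O)[C@H](O)[C@H]1OS(=O)(=O)O` gives 41 nM in this assay, the higher of the two numbers reported; its gap to compound 2 lies beyond the usual scatter, so compound 3 binds less tightly than compound 2, while compound 1 stands apart without a number. Compound 4 `CC(=O)N[C@H]1[C@@H](OC[C@@H](O)[C@@H](O)[C@H](O)[C@@H](O)CNc2cccc(NC(=O)CCCCC3CCSS3)c2)O[C@H](COS(=O)(=O)O)[C@H](OS(=O)(=O)O)[C@@H]1O[C@@H]1O[C@H](C(=O)O)[C@@H](O)[C@H](O)[C@H]1OS(=O)(=O)O` has not been measured yet. It differs from compound 3 in one place: sulfo in place of hydrogen on an oxygen on a saturated carbon. Compound 2 already carries such a (sulfooxy)methyl group and gives 16 nM in this assay, and compound 4 combines that group with everything compound 3 has. With compound 2 giving 16 nM, the step of a 4.1-fold lower number from compound 3 to compound 4 (0.61 log units; beyond the scatter) is expected to go toward a lower number and beyond the scatter. Compound 4 is therefore estimated at 10 nM, with a range from 3 nM to 30 nM.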

Compound 4, dissociation constant: 21 nM
For compound 4 the middle estimate is 2.1-fold (0.32 log units) below the measured one, within the range that was stated.
By their numbers in this assay, from the lowest: compounds 2, 4 and 3 (each within the scatter of the next, the first and the last beyond it).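

Changing hydroxymethyl to (sulfooxy)methyl on compound 3 gives a 2.0-fold lower number from compound 3 to compound 4 (0.29 log units; within the scatter) in this assay and so makes no difference that can be told from the scatter. Adding the other sulfo group likewise gives a 1.3-fold higher number from compound 2 to compound 4 (0.12 log units; within the scatter) and so shows that, with either of these extra sulfo groups already in place, the second brings no readable effect on binding, though compound 1, which has neither, gives "not active" (no number reported) in this assay. No measurement at hand explains why the second sulfo group adds so little.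

The compounds shown leave open whether a phosphate in place of the sulfo group would read the same on this oxygen. They also leave open how an amine in place of the hydroxy group would read at this position.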